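The source may hold more compounds than are shown below. What is called first, only, known or untested is meant among the compounds shown, and "the series" means these compounds.

In an ADME assay on MIA PaCa-2 cells (Homo sapiens) for cytotoxicity, read by MTT assay, with a stated time of 72 h (on this read-out lower numbers stand for stronger inhibition and higher numbers for weaker inhibition), compound 1, `COc1ccc(C2=C(c3cc(OC)c(OC)c(OC)c3)C(=O)CC2O[SiH2]C(C)(C)C)cc1`, gives > 100 ug/mL. That value is a limit of the assay and not a number, so compound 1 has no measured potency, only a boundary. Within the data shown here, the one other compound tested so far, compound 2, `COc1ccc(C2=C(c3cc(OC)c(OC)c(OC)c3)C(=O)C(OC(C)=O)C2)cc1F`, has a true reading of 39.5 ug/mL and carries changes at more than one place on the shared core.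

Compound 3, `COc1ccc(C2=C(c3cc(OC)c(OC)c(OC)c3)C(=O)CC2O[SiH2]C(C)(C)C)cc1OC`, departs from compound 1 at a single point: methoxy in place of hydrogen on an aromatic carbon. This is methoxy in place of hydrogen on an aromatic carbon, which turns 4-methoxyphenyl into 3,4-dimethoxyphenyl.

Among the measured compounds shown here, no measured pair shows what this change does, so any forecast in this assay is loose. If there is a move, a small one toward stronger inhibition is expected, and it may not rise beyond the scatter. Compound 3 could also end up reported only as a limit. The expected size of the change is an at least 1.1-fold lower number from compound 1 to compound 3 (0.04 log units; that floor lies within the scatter). The reading for compound 2 of 39.5 ug/mL helps set the lower end of the expected range. For compound 3 the estimated value is 90 ug/mL, with an expected range from 40 ug/mL to 150 ug/mL.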

Compound 3, half-maximal inhibitory concentration: > 100 ug/mL
Compound 3: no number, only a limit; the forecaster's own chance of this, stated with the estimate: 50%; middle value at least 1.1-fold (0.04 log units) from the limit.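

Compound 1 and compound 3 each end at a limit of the assay and not at a number, so the step between them cannot be read: the limit of > 100 ug/mL in this assay, at which 2 of the 3 values shown sit.

The compounds shown leave open whether turning 4-methoxyphenyl into 3,4-dimethoxyphenyl changes inhibition at all and, if it does, in which direction.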